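A few compounds are considered here, and "the series" means these few. Any claim that something is new, unique, unknown or untested is made for them only; others in the source may bear on it.

Series notes. The shared core is carried by compound 1 `N#Cc1c(-c2ccccc2)cn(-c2ccc(S(=O)(=O)Nc3nccs3)cc2)c1N` and by compound 2 `N#Cc1c(-c2ccccc2)cn(-c2ccc(S(=O)(=O)Nc3nccs3)cc2)c1NC(=O)CCC(=O)O`, which differ in one place only. In a functional assay on MCF7 cells (Homo sapiens) for inhibition, read by sulforhodamine B assay, with a stated time of 24 h (on this read-out lower numbers stand for stronger inhibition and higher numbers for weaker inhibition), compound 1 gives 3490 nM and compound 2 gives 9120 nM. For the measured compounds named here, the one measured step so far is a 2.6-fold higher number from compound 1 to compound 2 (0.42 log units; beyond the scatter). Going by the values given here, compound 2 thus stands with the higher of the two numbers in this assay, and compound 1 is its only neighbour.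

Compound 3 `N#Cc1c(-c2ccccc2)cn(-c2ccc(S(=O)(=O)Nc3nccs3)cc2)c1N1C(=O)CCC1=O` is the next candidate. Its change from compound 2 is 2,5-dioxopyrrolidin-1-yl in place of ((2-carboxyethyl)carbonyl)amino on an aromatic carbon. Among the compounds with values here, no measured pair shows this change itself; the only step that bears on it is a 2.6-fold higher number from compound 1 to compound 2 (0.42 log units; beyond the scatter), made at the same aromatic carbon, and it was modest. The expected step is therefore a 1.3-fold lower number from compound 2 to compound 3 (0.11 log units; within the scatter), not clearly beyond the scatter in either direction. Compound 3 is expected at 7000 nM in this assay, with a range from 2500 nM to 20000 nM.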

Compound 3, half-maximal inhibitory concentration: 6710 nM
Estimate against measurement, compound 3: 1.0-fold (0.02 log units) above; the measured number falls inside the stated range.
By their numbers in this assay, from the lowest: compounds 1, 3 and 2 (each within the scatter of the next, the first and the last beyond it).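

In this assay, 2,5-dioxopyrrolidin-1-yl, with 0 hydrogen-bond donors and one five-membered non-aromatic ring, in place of ((2-carboxyethyl)carbonyl)amino, with 2 hydrogen-bond donors and no ring, gives a 1.4-fold lower number from compound 2 to compound 3 (0.13 log units; within the scatter); at this aromatic carbon, closing the chain into a ring therefore makes no readable difference. In place of amino, the same ring gives a 1.9-fold higher number from compound 1 to compound 3 (0.28 log units; within the scatter), so compound 3 cannot be told apart from either neighbour, even though those neighbours are separated by a 2.6-fold higher number from compound 1 to compound 2 (0.42 log units; beyond the scatter). Nothing available accounts for these results. Going by these compounds, it remains open whether an acetylamino group or a longer chain ending in a carboxylic acid at this carbon would give a step beyond the scatter from compound 1. On these data alone, whether these small steps hold with a group other than phenyl on the shared core is also open.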